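The compounds below may be only part of what the source reports. "The series", "measured", "known", "first", "only" and "open" are said of these compounds alone.

Within the data shown here, in an ADME assay on microsomes from liver (Rattus norvegicus) for metabolic stability, read by LC-MS, using NADPH, at 37 degrees C (on this read-out lower numbers stand for a shorter-lived compound and higher numbers for a longer-lived compound), compound 2 (`COc1cccc(Cl)c1-c1nc(CN2CCC(C(=O)NCCCN3C[C@H](C)C[C@H](C)C3)CC2)c(C)o1`) gives 0.055 h and stands lowest of the two numbers so far, while compound 1 (`Cc1oc(-c2ccc(F)cc2)nc1CN1CCC(C(=O)NCCCN2C[C@H](C)C[C@H](C)C2)CC1`) gives 0.468 h as the only other measurement.

Compound 3 (`Cc1ccc(-c2nc(CN3CCC(C(=O)NCCCN4C[C@H](C)C[C@H](C)C4)CC3)c(C)o2)cc1C`) carries 3,4-dimethylphenyl in place of 2-chloro-6-methoxyphenyl on an aromatic carbon of a five-membered aromatic ring with 1 nitrogen and 1 oxygen (3,4-dimethylphenyl in place of 2-chloro-6-methoxyphenyl on an aromatic carbon).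

Among the measured compounds shown here, one measured step bears on this change. It runs an 8.5-fold lower number from compound 1 to compound 2 (0.93 log units; beyond the scatter) and brings in the same 2-chloro-6-methoxyphenyl that leaves here, with 4-fluorophenyl as the group replaced. Read in reverse, that step points upward for compound 3. However, 3,4-dimethylphenyl is not 4-fluorophenyl, and no measured compound carries it, so only part of that size is assumed to return.

The expected change is a 4.0-fold higher number from compound 2 to compound 3 (0.60 log units; beyond the scatter) in this assay and is taken as an upward move, smaller than the one measured between the first two compounds. In this assay the estimate for compound 3 is 0.22 h (expected range 0.07 h to 0.6 h).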

Compound 3, half-life: > 0.5 h
Compound 3 ended at the assay's limit (the forecaster's own chance of this, stated with the estimate: 3%); middle value at least 2.2-fold (0.35 log units) away from the limit.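

In this assay, 3,4-dimethylphenyl in place of 2-chloro-6-methoxyphenyl on the aromatic carbon gives an at least 9.0-fold higher number from compound 2 to compound 3 (0.95 log units; beyond the scatter), so the low number of compound 2 is now set against two other aryl groups at this position, not only 4-fluorophenyl. The reading for compound 3 is a limit of the assay and not a number: the limit of > 0.5 h in this assay, at which 1 of the 3 values shown sits. Against 4-fluorophenyl the step reads an at least 1.0-fold higher number from compound 1 to compound 3 (0.02 log units; that floor lies within the scatter), and with that floor within the scatter, the data do not place 3,4-dimethylphenyl relative to 4-fluorophenyl beyond showing that compound 3 does not fall to the level of compound 2.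

The compounds shown leave open which part of 2-chloro-6-methoxyphenyl goes with the low number, since the chloro and methoxy groups appear only together; a phenyl carrying a single methoxy group or a single chlorine would separate them. Going by these compounds, how far compound 3 lies past its limit also stays open, as does whether an unsubstituted phenyl at this position would track with compound 1 and compound 3 or with compound 2.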